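The source may report more compounds than this note shows. Statements on the series, on what has been measured and on what is new or still open speak of the compounds shown alone.

Compound 1 `CNc1nc(Cl)nc(N[C@@H](C)c2ccccc2)n1` sits in the middle of a small set measured in an ADME assay on the whole organism for inhibition, with Echinochloa crus-galli var. formosensis as the target, with a stated time of 4 days; a lower number here means a stronger inhibitor, a higher number a weaker inhibitor: compound 1 gives 26900 nM. Its nearest neighbour is compound 2 `CC[C@H](C)Nc1nc(Cl)nc(N[C@H](C)c2ccccc2)n1`, which in this assay gives 52500 nM, a gap within the scatter; the furthest is compound 3 `CCCN(C)c1nc(Cl)nc(N[C@H](C)c2ccccc2)n1`, which in this assay gives 9770 nM, a gap beyond the scatter. Among the compounds with values here, the one single-point step in the set, a 5.4-fold lower number from compound 2 to compound 3 (0.73 log units; beyond the scatter), is a modest one. Compound 4 `CCCCNc1nc(Cl)nc(N[C@@H](C)c2ccccc2)n1` differs from compound 1 by propyl in place of hydrogen on a saturated chain carbon bound to a nitrogen on an aromatic ring. Within the data shown here, no step in the set matches this change exactly; the step from compound 2 to compound 3 concerns a different pair of groups on the same nitrogen and says only that such swaps can move the number modestly. Compound 4 is therefore expected to lie close to compound 1, with the step of a 1.3-fold lower number from compound 1 to compound 4 (0.13 log units; within the scatter) anticipated to be small and of uncertain direction. The estimate for compound 4 in this assay is 20000 nM, within a range of 7000 nM to 55000 nM.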

Compound 4, half-maximal inhibitory concentration: 12900 nM
Beside the measured number, compound 4's estimate is 1.6-fold (0.19 log units) above it; the range from low to high includes it.
By their numbers in this assay, from the lowest: compounds 3 and 4 (each within the scatter of the next); then compounds 1 and 2 (each within the scatter of the next).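

In this assay the change from methylamino to butylamino brings a 2.1-fold lower number from compound 1 to compound 4 (0.32 log units; beyond the scatter) and so shows that lengthening the chain on this nitrogen, with the nitrogen's own hydrogen kept, moves the number by a modest amount towards stronger inhibition. The earlier step of a 5.4-fold lower number from compound 2 to compound 3 (0.73 log units; beyond the scatter) exchanged one pair of groups on the nitrogen for another and so could not show the effect of adding propyl in place of hydrogen on this saturated chain carbon alone. Nothing measured here explains the shift.

From the compounds shown here alone, whether a longer chain such as hexyl would carry the trend further, or whether it would level off or reverse, stays open. Also open, going by these compounds, is how a hydroxyl or an amine at the end of the butyl chain would read at this position.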